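The source may hold more compounds than are shown below. What is called first, only, known or untested is meant among the compounds shown, and "the series" means these compounds.

Measured so far:
compound 1 `CN(C)CCn1cnnc1-c1cc(Oc2ccc(NC(=O)N/N=C/c3ccc(F)cc3Cl)cc2F)ccn1` — 1120 nM
compound 2 `CN(C)CCn1cnnc1-c1cc(Oc2ccc(NC(=O)N/N=C/c3cc(Br)c(O)c(Br)c3)cc2F)ccn1` — a limit only, > 100000 nM
compound 3 `CN(C)CCn1cnnc1-c1cc(Oc2ccc(NC(=O)N/N=C/c3ccc(F)cc3)cc2F)ccn1` — 1790 nM

In a functional assay on A549 cells (Homo sapiens) for cytotoxicity, read by MTT assay, with a stated time of 72 h (a higher number here means a weaker inhibitor, a lower number a stronger inhibitor), compound 1 gives the lowest of the two numbers; compound 3 stands within the scatter of it, a 1.6-fold higher number from compound 1 to compound 3 (0.20 log units; within the scatter). Compound 2 sits at the limit of > 100000 nM in this assay, at which 1 of the 3 values shown sits. The step from the 2-chloro-4-fluorophenyl to the 3,5-dibromo-4-hydroxyphenyl is large, an at least 89-fold higher number from compound 1 to compound 2 (1.95 log units; beyond the scatter), as is the return, an at least 55-fold lower number from compound 2 to compound 3 (1.74 log units; beyond the scatter).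

Compound 4 `COc1cc(/C=N/NC(=O)Nc2ccc(Oc3ccnc(-c4nncn4CCN(C)C)c3)c(F)c2)ccc1O` differs from compound 1 thus: 4-hydroxy-3-methoxyphenyl in place of 2-chloro-4-fluorophenyl on a carbon with a double bond to nitrogen. Among the measured compounds shown here, the only bearing step is that to compound 2, where a 4-hydroxyphenyl also entered, though there flanked by bromines rather than a methoxy. A clearly higher number than compound 1 is therefore expected, a 13-fold higher number from compound 1 to compound 4 (1.13 log units; beyond the scatter). Compound 4 is estimated at 15000 nM, within 2500 nM to 100000 nM.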

Compound 4, half-maximal inhibitory concentration: > 100000 nM
Compound 4: only a limit was reported; the forecaster's own chance of this, stated with the estimate: 30%; middle value at least 6.6-fold (0.82 log units) from the limit.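

In this assay, the 4-hydroxy-3-methoxyphenyl on the carbon with a double bond to nitrogen gives an at least 89-fold higher number from compound 1 to compound 4 (1.95 log units; beyond the scatter) and an at least 55-fold higher number from compound 3 to compound 4 (1.74 log units; beyond the scatter). The loss seen with the 3,5-dibromo-4-hydroxyphenyl therefore does not require bromine: both compounds shown with a hydroxy-bearing aryl group lose measurable activity, and neither compound with only halogen on the ring does. The step between compound 2 and compound 4 cannot be read, as both values are limits and not numbers: the limit of > 100000 nM in this assay, at which 2 of the 4 values shown sit.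

Whether the hydroxy group alone accounts for the loss remains open. A 4-methoxyphenyl or a 4-aminophenyl at this place would test that.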